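From a trifluoromethyl to two fluorines

This account rests on a few compounds, and the source may have more. Where it says the series, first, only, none or still open, it means among the compounds named here.

Of the compounds shown here, three sharing one core have been measured in a functional assay on cardiac atrium for agonist activity at histamine H2 receptor (Cavia porcellus); on this read-out lower numbers stand for lower potency and higher numbers for higher potency (the scale is a negative logarithm). Compound 1 `N=C(NCCCc1c[nH]cn1)NCCC(c1ccc(F)cc1)c1ccccn1` gives 8.01, compound 2 `N=C(NCCCc1c[nH]cn1)NCCC(c1cccc(F)c1)c1ccccn1` gives 7.88, and compound 3 `N=C(NCCCc1c[nH]cn1)NCCC(c1cccc(C(F)(F)F)c1)c1ccccn1` gives 7.43. Compound 3 thus stands lowest of the three: the step of a number 0.58 log units lower from compound 1 to compound 3 (beyond the scatter) and the step of a number 0.45 log units lower from compound 2 to compound 3 (beyond the scatter) both go beyond the scatter, while the step of a number 0.13 log units lower from compound 1 to compound 2 (within the scatter) does not.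

Compound 4 `N=C(NCCCc1c[nH]cn1)NCCC(c1cc(F)cc(F)c1)c1ccccn1` has not yet been measured in this assay. It differs from compound 3 in one place: 3,5-difluorophenyl in place of 3-(trifluoromethyl)phenyl on a saturated chain carbon bound to an aromatic carbon and a saturated chain carbon. Within the data shown here, two measured steps bear on this change. The step of a number 0.45 log units lower from compound 2 to compound 3 (beyond the scatter) shows what happened when a single fluoro on the ring gave way to trifluoromethyl, and compound 4 undoes that exchange while carrying a second fluoro. The step of a number 0.13 log units lower from compound 1 to compound 2 (within the scatter) shows that 3-fluorophenyl in place of 4-fluorophenyl stayed within the scatter, so the placement of a fluoro mattered little there. A modest rise is therefore expected, roughly the reverse of the earlier drop, estimated as a number 0.42 log units higher from compound 3 to compound 4 (beyond the scatter). Compound 4 is accordingly expected to reach about 7.85, with a likely range from 7.45 to 8.25.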

Compound 4, negative logarithm of the half-maximal effective concentration: 8.05
Compound 4: the middle estimate sits 0.20 log units below what was measured; the measured number falls inside the stated range.
By their numbers in this assay, from the lowest: compound 3; then compounds 2, 1 and 4 (each within the scatter of the next).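

Setting 3,5-difluorophenyl in place of 3-(trifluoromethyl)phenyl gives the step of a number 0.62 log units higher from compound 3 to compound 4 (beyond the scatter) and so shows that the fall seen with trifluoromethyl does not persist once two fluoro groups stand on the ring instead. The second fluoro itself brings no readable change in this assay: the step of a number 0.17 log units higher from compound 2 to compound 4 (within the scatter) and the step of a number 0.04 log units higher from compound 1 to compound 4 (within the scatter) both leave compound 4 level with the singly fluorinated compounds, which makes compound 3 the only one of the four set apart from the rest. No measured property of these groups is available to explain why the trifluoromethyl compound stands apart.

As far as these compounds go, whether a ring carrying chloro, methyl or methoxy would group with the fluoro compounds or with compound 3 remains open. Also open is how a plain phenyl with no substituent at all would behave, as every ring shown here carries fluorine in some form, and whether the same grouping would hold in any other read-out.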